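The compounds below may be only part of what the source reports. "The series", "measured", "known", "first", "only" and "open" are said of these compounds alone.

Working notes on the series. Compound 1 `O=C(CCCCC1CCSS1)NCc1cn(CCCOc2ccc3cc(-c4ccc(Br)cc4)c(=O)oc3c2)nn1`, compound 2 `O=C(CCCCC1CCSS1)NCc1cn(CCCOc2ccc3cc(-c4ccc(Cl)cc4)c(=O)oc3c2)nn1` and compound 3 `O=C(CCCCC1CCSS1)NCc1cn(CCCCOc2ccc3cc(-c4ccc(Br)cc4)c(=O)oc3c2)nn1` have been measured in a functional assay on PC-12 cells (Rattus norvegicus) for cytotoxicity, read by MTT assay, with stated times of 3 h and 2 h, tested at 5 uM; on this read-out higher numbers stand for a stronger effect at the one concentration tested and lower numbers for a weaker effect; compound 4 `O=C(CCCCC1CCSS1)NCc1cn(CCCCOc2ccc3cc(-c4ccc(Cl)cc4)c(=O)oc3c2)nn1` has not. In this assay compound 1 gives 57.3%, compound 2 gives 60.6%, and compound 3 gives 40.5%. Compound 3 holds the lowest number of the three, with compound 1 nearest and compound 2 furthest, both differences beyond the scatter. The difference between the core of compound 1 and the core of compound 3 is not broken down here.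

Compound 2 differs from compound 1 by chloro in place of bromo on an aromatic carbon and this change gave a number 3.3 percentage points higher from compound 1 to compound 2 (within the scatter). Compound 4 differs from compound 3 by chloro in place of bromo on an aromatic carbon, which is the same change at the same place; it occurs twice among the compounds shown. For the measured compounds named here, the only guide to what this change does in this assay is the single step from compound 1 to compound 2, which stayed within the scatter, and nothing shows how the change behaves on the core of compound 3. The expected step is therefore a number 3 percentage points higher from compound 3 to compound 4 (within the scatter), set beside the measured one, because the earlier step of a number 3.3 percentage points higher from compound 1 to compound 2 (within the scatter) was small. Compound 4 is expected at 43.5%, between 30% and 57%. This estimate rests on compound 3 at 40.5% as the starting point, with a range wide enough to cover the ordinary scatter and the uncertainty of carrying one small step onto a different core.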

Compound 4, a percentage reported as activity, at one concentration (the size of the read-out at that concentration, not a potency): 52%
Beside the measured number, compound 4's estimate is 8.5 percentage points below it, and the stated range covers the measured number.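

In this assay, the change from 4-bromophenyl to 4-chlorophenyl gave a number 11.5 percentage points higher from compound 3 to compound 4 (beyond the scatter), so on this core the step clears the scatter, whereas on the core of compound 1 it did not. The two steps point the same way, and the gap between them gives no ground for treating the change as behaving differently on the two cores: the same change on two cores in this assay, a number 3.3 percentage points higher (within the scatter) from compound 1 to compound 2 and a number 11.5 percentage points higher (beyond the scatter) from compound 3 to compound 4, 8.2 percentage points apart, within the scatter of two such steps. For the compounds shown here, this supports carrying the direction of the change from one core to the other within these two pairs, but it does not fix a size for the step, and it does not show that the core has no influence, since any such influence cannot be told apart from scatter with only two pairs.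

The compounds shown leave open whether the same direction holds for other groups at this place on the aromatic ring, such as fluoro, methoxy or trifluoromethyl, or for an unsubstituted phenyl. Going by these compounds alone, also open is how the bromo and chloro pair behaves with a longer chain than the one in compound 3 and compound 4.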